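A few compounds are considered here, and "the series" means these few. Any claim that something is new, unique, unknown or untested is made for them only; others in the source may bear on it.

Of the compounds shown here, three have been tested so far in a functional assay on HL-60 cells (Homo sapiens) for antiproliferative activity, read by XTT assay, with a stated time of 72 h; on this read-out higher numbers stand for weaker inhibition and lower numbers for stronger inhibition. Compound 1 `COc1ncnc2c1c(-c1ccoc1)cn2[C@@H]1O[C@H](CO)[C@@H](O)[C@H]1O` gives 150 nM. Compound 3 `COc1ncnc2c1c(-c1cccs1)cn2[C@@H]1O[C@H](CO)[C@@H](O)[C@H]1O` differs from compound 1 in one place, (thiophen-2-yl in place of furan-3-yl on an aromatic carbon), and in this assay compound 3 gives 80 nM. The step is a 1.9-fold lower number from compound 1 to compound 3 (0.27 log units; within the scatter), so these two numbers cannot be told apart here. Compound 2 `Cc1ncnc2c1c(-c1ccoc1)cn2[C@@H]1O[C@H](CO)[C@@H](O)[C@H]1O` differs from compound 1 in another place, (methyl in place of methoxy on an aromatic carbon). For compound 2 this assay reports only a limit, > 15000 nM. The step is an at least 100-fold higher number from compound 1 to compound 2 (2.00 log units; beyond the scatter), with the number sitting at the limit of > 15000 nM in this assay, at which 1 of the 3 values shown sits.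

Compound 4 `Cc1ncnc2c1c(-c1cccs1)cn2[C@@H]1O[C@H](CO)[C@@H](O)[C@H]1O` has not yet been measured. It differs from compound 3 by methyl in place of methoxy on an aromatic carbon. This is the same change that separates compound 1 from compound 2, made here on the core that carries thiophen-2-yl instead of furan-3-yl. For compound 4 a step of similar size is expected, a 190-fold higher number from compound 3 to compound 4 (2.27 log units; beyond the scatter), because the earlier step was an at least 100-fold higher number from compound 1 to compound 2 (2.00 log units; beyond the scatter). Such a step would carry compound 4 to the region where this assay stops reporting a number. Compound 4 is therefore estimated at 15000 nM in this assay, with a likely range from 4000 nM to 60000 nM and a fair chance that only a limit is reported.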

Compound 4, half-maximal inhibitory concentration: 5730 nM
Estimate against measurement, compound 4: 2.6-fold (0.42 log units) above; low and high end bracket the measured number.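

In this assay, methyl in place of methoxy on the core carrying thiophen-2-yl gives a 72-fold higher number from compound 3 to compound 4 (1.86 log units; beyond the scatter), so the same change raises the number strongly on both cores shown, and the two steps can be set side by side only loosely: the same change on two cores in this assay, an at least 100-fold higher number (2.00 log units; beyond the scatter) from compound 1 to compound 2 and a 72-fold higher number (1.86 log units; beyond the scatter) from compound 3 to compound 4; the limit leaves it open whether they differ

Read the other way, thiophen-2-yl in place of furan-3-yl on the core carrying methyl gives an at least 2.6-fold lower number from compound 2 to compound 4 (0.41 log units; beyond the scatter), but this does not establish that the effect of that swap depends on the core: the same change on two cores in this assay, a 1.9-fold lower number (0.27 log units; within the scatter) from compound 1 to compound 3 and an at least 2.6-fold lower number (0.41 log units; beyond the scatter) from compound 2 to compound 4; the limit leaves it open whether they differ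

The value of compound 2 is a limit and not a number; the two cores share the direction of the methoxy-to-methyl change, while an equal size of the step is not shown and no core beyond these two is covered.

The compounds shown carry only methoxy or methyl in the place that was changed, which leaves open where an amine, an ethoxy group or a longer chain would fall in this assay. They also carry only furan-3-yl or thiophen-2-yl in the other place that varies, which leaves open whether a similarly large step would appear with a phenyl ring there.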